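The compounds below may be only part of what the source reports. "The series", "measured", "known", "first", "only" and "open" are said of these compounds alone.

For the measured compounds named here, compound 1 `Cc1cc(O)c(C(C)C)cc1-c1cc(-c2ccccc2Cl)c(C#N)c(=O)[nH]1` gives 26% in a functional assay for inhibition, tested at 60 ug/mL (a higher number here means a stronger effect of the compound at the concentration tested, a lower number a weaker effect), the lowest of the two numbers so far; compound 2 `COc1ccc(-c2cc(-c3cc(C(C)C)c(O)cc3C)[nH]c(=O)c2C#N)c(OC)c1` gives 48.5%, and the one measured step is a number 22.5 percentage points higher from compound 1 to compound 2 (beyond the scatter). Compound 3 `Cc1cc(O)c(C(C)C)cc1-c1cc(-c2ccco2)c(C#N)c(=O)[nH]1` differs from compound 1 by furan-2-yl in place of 2-chlorophenyl on an aromatic carbon. Going by the values given here, no measured step exchanges the 2-chlorophenyl for a five-membered aromatic ring, so only the step to compound 2 bears on this aromatic carbon, and it was modest. A smaller shift is expected here, a number 4 percentage points higher from compound 1 to compound 3 (within the scatter), with the direction uncertain. Compound 3 is therefore estimated at 30%, ranging from 12% to 50%.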

Compound 3, a percentage reported as inhibition, at one concentration (the size of the read-out at that concentration, not a potency): 55.2%
Estimate against measurement, compound 3: 25.2 percentage points below, outside the stated range (above it).
By their numbers in this assay, from the lowest: compound 1; then compounds 2 and 3 (each within the scatter of the next).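

In this assay, furan-2-yl in place of 2-chlorophenyl gives a number 29.2 percentage points higher from compound 1 to compound 3 (beyond the scatter) on this carbon opposite the ring nitrogen, so a five-membered aromatic ring with one hetero atom is tolerated here. Furan-2-yl in place of 2,4-dimethoxyphenyl gives a number 6.7 percentage points higher from compound 2 to compound 3 (within the scatter) and separates neither group, despite the different ring size and heavy-atom count. No available evidence accounts for these results. Whether the gain depends on losing the chlorine remains open, since unsubstituted phenyl is not among the compounds shown. Thiophen-2-yl or a saturated ring such as piperidine at this carbon also remains untested here.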